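Hepatocyte clearance notes: hydroxy to methoxy on compound 3

The source may hold more compounds than are shown below. What is called first, only, known or untested is meant among the compounds shown, and "the series" means these compounds.

Measured in an ADME assay on cells (Hepatocyte, Homo sapiens) for metabolic stability, read by LC-MS, with a stated time of 120 min; a lower number here means slower removal, a higher number faster removal of the compound:

compound 1 `CC(=O)Nc1c(F)cc(C(=O)N[C@H]2CC[C@H](O)CC2)cc1O[C@@H](C)c1ccccc1`: 2.8 mL/min
compound 2 `CNC(=O)c1cc(C(=O)NC2CC2)cn(Cc2cccc3[nH]ccc23)c1=O`: 2.9 mL/min
compound 3 `CNC(=O)c1cc(C(=O)N[C@H]2CC[C@H](O)CC2)n([C@@H](C)c2ccccc2)n1`: < 0.5 mL/min

Compound 1 and compound 2 sit within the scatter of each other, so no order between them is read. The value of compound 3 in this assay is a limit of the assay and not a number. Compound 3 is the only one of the three that rests at the limit of < 0.5 mL/min in this assay, at which 1 of the 3 values shown sits, so its true position is known only as lying under that limit, and any step from it can be sized only from above.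

Compound 4 `CNC(=O)c1cc(C(=O)N[C@H]2CC[C@H](OC)CC2)n([C@@H](C)c2ccccc2)n1` differs from compound 3 by methyl in place of hydrogen on an oxygen on a saturated carbon; the rest of the structure is kept. Among the measured compounds shown here, no measured pair shows this change, so there is no step to lean on.

Because compound 3 gives < 0.5 mL/min, the step of an at least 2.4-fold higher number from compound 3 to compound 4 (0.38 log units; beyond the scatter) in this assay is expected to run toward faster removal, of a size that may or may not pass the scatter, with a fair chance that compound 4 is also reported only as a limit. Compound 4 is estimated at 1.2 mL/min, with a range from 0.4 mL/min to 3.5 mL/min.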

Compound 4, intrinsic clearance in a liver preparation (reported as CLH), per the amount of preparation that the assay uses: < 0.45 mL/min
Compound 4 was reported as a limit (the forecaster's own chance of this, stated with the estimate: 30%); at least 2.6-fold (0.42 log units) between middle value and limit.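

In this assay compound 3 gives < 0.5 mL/min, a limit of the assay. Among the compounds shown here, compound 4 gives < 0.45 mL/min, also a limit of the assay, and no step between these two compounds can be read. The compounds shown leave open whether hydroxy to methoxy on this structure changes the clearance at all, and in which direction.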